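The source may hold more compounds than are shown below. What is called first, only, known or untested is meant among the compounds shown, and "the series" means these compounds.

For the measured compounds named here, the three compounds measured so far share one core and differ in the chain on the triple bond. Going by the values given here, in a functional assay on HEL cells (Homo sapiens) for cytotoxicity (on this read-out higher numbers stand for lower toxicity in this test and lower numbers for higher toxicity in this test), compound 1 `CCCCCCCCCCC#Cc1cc2cn([C@@H]3O[C@H](CO)[C@@H](O)[C@@H]3O)c(=O)nc2o1` gives 116000 nM, the only exact number of the three. Compound 2 `CCCCC#Cc1cc2cn([C@@H]3O[C@H](CO)[C@@H](O)[C@@H]3O)c(=O)nc2o1`, with a shorter chain, reads > 144000 nM, which is a limit of the assay. Compound 3 `CCCCCCC#Cc1cc2cn([C@@H]3O[C@H](CO)[C@@H](O)[C@@H]3O)c(=O)nc2o1`, also with a shorter chain, reads > 53000 nM, again a limit. Among the compounds with values here, the one step with a readable floor is an at least 1.2-fold higher number from compound 1 to compound 2 (0.09 log units; that floor lies within the scatter). The other two are a step that the limit leaves unreadable from compound 1 to compound 3 and a step that the two limits leave unreadable from compound 2 to compound 3.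

Compound 4 `CCCCCCCCCCC#Cc1cc2cn([C@@H]3O[C@H](CO)[C@@H](O)[C@H]3O)c(=O)nc2o1` keeps the long chain of compound 1 and changes something else: the two compounds have the same atoms and bonds and differ only in configuration as drawn: 1 of 4 stereo elements differ; a stereocentre at a saturated ring carbon is drawn S in compound 1 and R in compound 4. A single stereocentre at a saturated ring carbon is drawn S in compound 1 and R in compound 4. Within the data shown here, none of the measured steps changes configuration, so they bear on this change only indirectly. They show no chain step beyond the scatter, and they give no direction for a change in a ring stereocentre. In this assay, the expectation is therefore no step beyond the scatter, with the value staying close to that of compound 1. The expected change is a 1.1-fold lower number from compound 1 to compound 4 (0.02 log units; within the scatter). For compound 4 the estimated value is 110000 nM, with an expected range from 45000 nM to 250000 nM.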

Compound 4, half-maximal cytotoxic concentration: 44000 nM
For compound 4 the middle estimate is 2.5-fold (0.40 log units) above the measured one, outside the stated range (below it).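

In this assay, a change at a single stereocentre on a saturated ring carbon gives a 2.6-fold lower number from compound 1 to compound 4 (0.42 log units; beyond the scatter), which means higher toxicity in this test. The earlier compounds differ only in the chain on the triple bond, and the one step among them with a readable floor does not establish a change beyond the scatter, so this pair gives the first clear difference among the compounds shown, though a modest one. That difference can be attributed to the drawn configuration at this ring carbon because no atom or bond changes between the two compounds: the fact that compounds 1 and 4 differ only in the configuration as drawn

The compounds shown leave open whether the same change in configuration gives a step of similar size and direction on the shorter chains of compound 2 and compound 3, since no partner with the changed configuration is shown for either. They also leave open whether a longer chain, or a chain ending in an amine, would keep, enlarge or remove this step, and they say nothing about why the configuration at this ring carbon changes the read-out.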